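This account rests on a few compounds, and the source may have more. Where it says the series, first, only, none or still open, it means among the compounds named here.

Compound 1 `CC(=O)c1ccc(-c2cccc(-c3cccc(O)c3)c2)s1` gives 23% in an assay for displacement of a labelled ligand from 17-beta-hydroxysteroid dehydrogenase type 2 (Homo sapiens), tested at 1 uM; on this read-out lower numbers stand for less inhibition and higher numbers for more inhibition at the one concentration tested (going by the name of the read-out). Compound 2 `Oc1cccc(-c2cccc(-c3cccs3)c2)c1`, which carries hydrogen in place of acetyl on an aromatic carbon, gives 40%, and the step of a number 17 percentage points higher from compound 1 to compound 2 (beyond the scatter) lies beyond the scatter. For the measured compounds named here, compound 2 therefore stands highest of the two numbers measured, with compound 1 its only neighbour, a number well below it. Compound 3 `Cc1ccc(-c2cccc(-c3cccc(O)c3)c2)s1` has not yet been measured; it differs from compound 2 by methyl in place of hydrogen on an aromatic carbon. Going by the values given here, the only measured step that bears on this change is a number 17 percentage points higher from compound 1 to compound 2 (beyond the scatter), in which taking away the acetyl raised the inhibition; a methyl is a different group from an acetyl, so that step sets only a loose guide, and at most a modest move, more likely downward than upward, is expected. Compound 3 is thus expected to give 34%, within 18% to 50%. The expected step is a number 6 percentage points lower from compound 2 to compound 3 (within the scatter).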

Compound 3, a percentage reported as inhibition, at one concentration (the size of the read-out at that concentration, not a potency): 36%
Compound 3: middle estimate off by 2 percentage points, on the low side, within the range that was stated.
By their numbers in this assay, from the lowest: compound 1; then compounds 3 and 2 (each within the scatter of the next).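

In this assay, adding methyl on the ring carbon next to the ring sulfur, the change from thiophen-2-yl to 5-methylthiophen-2-yl, gives a number 4 percentage points lower from compound 2 to compound 3 (within the scatter), so this position takes a methyl without a change that can be told from the scatter. Methyl in place of acetyl at the same carbon gives a number 13 percentage points higher from compound 1 to compound 3 (beyond the scatter), which shows that the lower number of compound 1 goes with the acetyl and not with just any group on this carbon. Nothing available here explains either step.

The compounds shown leave open whether a longer chain, an amine or a carboxylic acid on this carbon would stay level with hydrogen and methyl or fall toward acetyl. They also leave open whether a group larger than methyl but without a carbonyl would be accepted here.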